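The source may report more compounds than this note shows. Statements on the series, on what has been measured and on what is new or still open speak of the compounds shown alone.

- Compound 1 `COc1ccc(-c2nc3cnccn3c2Nc2cc(OC)c(OC)c(OC)c2)cc1` gives 75000 nM in an ADME assay on Vero cells (Chlorocebus sabaeus) for cytotoxicity, read by MTT assay; on this read-out higher numbers stand for lower toxicity in this test and lower numbers for higher toxicity in this test
- Compound 2 `COc1cc(Nc2c(-c3cccc(O)c3)nc3cnccn23)cc(OC)c1OC` gives 63000 nM in this assay
- Compound 3 `COc1cc(Nc2c(-c3ccc(Cl)cc3)nc3cnccn23)cc(OC)c1OC` gives 32000 nM in this assay

These three compounds share a core and differ in one aromatic group. Compound 3 stands at the low end of this small set, though only one of its two gaps is meaningful. There is a 2.3-fold lower number from compound 1 to compound 3 (0.37 log units; beyond the scatter), a modest step. There is also a 2.0-fold lower number from compound 2 to compound 3 (0.29 log units; within the scatter), so compound 2 cannot be told apart from it.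

The next compound, compound 4 `COc1cc(Nc2c(-c3ccc(F)cc3)nc3cnccn23)cc(OC)c1OC`, has fluoro in place of chloro on an aromatic carbon, para to a large group: fluoro in place of chloro on an aromatic carbon.

For the measured compounds named here, no measured compound yet carries fluoro, so no step shows this exact exchange. The closest evidence is what happened when this aromatic group was changed more broadly. Besides the two steps above, there is a 1.2-fold lower number from compound 1 to compound 2 (0.08 log units; within the scatter), which also stays within the scatter. Even the exchange of chloro for methoxy therefore gave only a modest step, and a swap of one halogen for another is expected to give no step beyond the scatter in this assay.

The estimate is a 1.3-fold higher number from compound 3 to compound 4 (0.12 log units; within the scatter), and this is an expectation only. For compound 4 the expected value is 42000 nM, with an estimated range from 20000 nM to 90000 nM.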

Compound 4, concentration lethal to 50% of the cells: 48000 nM
Estimate against measurement, compound 4: 1.1-fold (0.06 log units) below, within the range that was stated.
By their numbers in this assay, from the lowest: compounds 3, 4, 2 and 1 (each within the scatter of the next, the first and the last beyond it).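

In this assay, fluoro in place of chloro on this aromatic carbon, para to a large group, gives a 1.5-fold higher number from compound 3 to compound 4 (0.18 log units; within the scatter) and so leaves the two halogens indistinguishable here. The comparison with the other two compounds adds something new, as there is a 1.3-fold lower number from compound 2 to compound 4 (0.12 log units; within the scatter) and also a 1.6-fold lower number from compound 1 to compound 4 (0.19 log units; within the scatter) for fluoro in place of methoxy. Chloro in place of methoxy gave a 2.3-fold lower number from compound 1 to compound 3 (0.37 log units; beyond the scatter) and was the only step beyond the scatter, so that separation from methoxy does not extend to every halogen at this position.

The compounds shown leave open what an amine, a carboxylic acid or a longer chain would give at this place on the ring, as every group compared so far gives a number close to the others. They also leave open whether the two halogens would stay this close in any other test. Nothing measured here offers an explanation for these small differences.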